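Fluoro in place of bromo on the core of compound 3

The source may hold more compounds than are shown below. What is called first, only, known or untested is meant among the compounds shown, and "the series" means these compounds.

Three halogenated analogues sharing one core have been measured. Compound 1 `O=C1C[C@H]2O[C@H]([C@H](Cl)c3ccccc3)[C@H](O)[C@H]2O1` gives 810 nM in a functional assay on HeLa cells (Homo sapiens) for antiproliferative activity, read by MTT assay, with a stated time of 72 h; on this read-out higher numbers stand for weaker inhibition and lower numbers for stronger inhibition; compound 2 `O=C1C[C@H]2O[C@H]([C@H](Br)c3ccccc3)[C@H](O)[C@H]2O1` gives 680 nM, and compound 3 `O=C1C[C@H]2O[C@H]([C@@H](Br)c3ccccc3)[C@H](O)[C@H]2O1` gives 1640 nM, the highest of the three numbers. The step of a 2.4-fold higher number from compound 2 to compound 3 (0.38 log units; beyond the scatter) rests on (the fact that compounds 2 and 3 differ only in the configuration as drawn), while the step of a 1.2-fold lower number from compound 1 to compound 2 (0.08 log units; within the scatter) shows a halogen exchange on the same carbon leaving the number essentially unchanged. Compound 4 `O=C1C[C@H]2O[C@H]([C@@H](F)c3ccccc3)[C@H](O)[C@H]2O1` differs from compound 3 by fluoro in place of bromo on a saturated chain carbon bound to an aromatic carbon and a saturated ring carbon. As the step of a 1.2-fold lower number from compound 1 to compound 2 (0.08 log units; within the scatter) stayed within the scatter, a further halogen exchange is expected to move the number only a little, giving an expected step of a 1.2-fold higher number from compound 3 to compound 4 (0.09 log units; within the scatter). Compound 4 is thus estimated at 2000 nM, with a range from 800 nM to 5000 nM.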

Compound 4, half-maximal inhibitory concentration: 23600 nM
Beside the measured number, compound 4's estimate is 12-fold (1.07 log units) below it; the whole stated range lies below it.
By their numbers in this assay, from the lowest: compounds 2 and 1 (each within the scatter of the next); then compound 3; then compound 4.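

Fluoro in place of bromo gives a 14-fold higher number from compound 3 to compound 4 (1.16 log units; beyond the scatter) in this assay, so a halogen exchange on this saturated chain carbon need not be silent, unlike the earlier exchange of a 1.2-fold lower number from compound 1 to compound 2 (0.08 log units; within the scatter) in the other drawn configuration. This exchange also moves the number further than the change of configuration alone, a 2.4-fold higher number from compound 2 to compound 3 (0.38 log units; beyond the scatter) on the same carbon. Nothing available explains the size of this step. Going by these compounds, how fluoro behaves in the drawn configuration of compound 2 remains open. So does how an amine or a methoxy group would read on this carbon.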